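Swapping the sulfonyl aryl group on a thiazole amide series

The source may hold more compounds than are shown below. What is called first, only, known or untested is meant among the compounds shown, and "the series" means these compounds.

Compound 1 `O=C(Nc1ncc(C(Oc2ccc3cc(Br)ccc3c2)c2ccc(Cl)cc2)s1)c1ccc(F)cc1`: "not toxic" (no number reported)
Compound 2 `O=C(Nc1ncc(C(Oc2ccc3cc(Br)ccc3c2)c2ccc(Cl)cc2)s1)c1ccc(F)cc1Br`: > 50000 nM
Compound 3 `Cc1ccc(C)c(S(=O)(=O)Nc2ncc(C(Oc3ccc4cc(Br)ccc4c3)c3ccc(Cl)cc3)s2)c1`: > 50000 nM

Compound 1 is recorded in an ADME assay on HepG2 2.2.15 cells (Homo sapiens) for cytotoxicity (a higher number here means that more compound is tolerated, a lower number that less compound is tolerated), without a number, simply as "not toxic" (no number reported). Compound 2 reaches only a limit in this assay, > 50000 nM. Compound 3 likewise sits at a limit in this assay, > 50000 nM, so on the numbers shown compound 3 stands at the upper edge of what the assay reports, where (the limit of > 50000 nM in this assay, at which 2 of the 3 values shown sit). For the measured compounds named here, the one step between measured compounds, a step that the two limits leave unreadable from compound 2 to compound 3, therefore cannot be sized.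

Compound 4 `O=S(=O)(Nc1ncc(C(Oc2ccc3cc(Br)ccc3c2)c2ccc(Cl)cc2)s1)c1cccc2nsnc12` is the next member. It differs from compound 3 by a group of 9 heavy atoms (6 carbon, 2 nitrogen, 1 sulfur; one five-membered aromatic ring with 3 hetero atoms, one six-membered aromatic ring of carbon only) in place of a group of 8 heavy atoms (8 carbon; one six-membered aromatic ring of carbon only), on a sulfonyl sulfur. The only measured step that bears on this position, a step that the two limits leave unreadable from compound 2 to compound 3, is unreadable, and no shown value gives a direction for exchanging one aryl group for another on the sulfonyl sulfur. The expectation is therefore that compound 4 will again be tolerated up to the limit of this assay, with a step that the limit leaves unreadable from compound 3 to compound 4 that is expected to stay within the scatter. Compound 4 is estimated at 60000 nM, in a range from 25000 nM to 150000 nM.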

Compound 4, half-maximal cytotoxic concentration: "not toxic" (no number reported)
The entry for compound 4 holds no number, and the estimate cannot be compared.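

In this assay, for the compounds shown here, compound 4 is entered as "not toxic" (no number reported) and so gives no new step from compound 3 that can be read. Compound 3 remains at > 50000 nM which is a limit of the assay. The compounds shown leave open how exchanging the aryl group on the sulfonyl sulfur affects tolerated concentration.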